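The source may hold more compounds than are shown below. What is called first, only, known or untested is meant among the compounds shown, and "the series" means these compounds.

Values measured in a functional assay on KYSE-450 cells (Homo sapiens) for inhibition, read by MTT assay, with a stated time of 48 h (on this read-out higher numbers stand for weaker inhibition and lower numbers for stronger inhibition), are these:

- compound 1 (`COc1ccc(CNc2cc(OC)c(OC)c(OC)c2)cc1F`) gives 46200 nM
- compound 2 (`COc1ccc(CNc2cc(OC)c(OC)c(OC)c2)cc1`) gives 4890 nM

Of these two, compound 2 has the lower number, which makes it the stronger inhibitor, and its gap to compound 1 lies beyond the scatter. The next compound, compound 3 (`COc1ccc(CNc2cc(OC)c(OC)c(OC)c2)cc1N`), keeps the shared core and changes one place: amino in place of hydrogen on an aromatic carbon, ortho to a methoxy group.

Within the data shown here, only one measured step concerns this same place, hydrogen in place of fluoro, and it is a 9.4-fold lower number from compound 1 to compound 2 (0.98 log units; beyond the scatter). Among the measured compounds shown here, that step shows that a change here can shift the number, but it says nothing direct about amino, which no measured compound carries. A step of similar or smaller size is therefore expected in this assay, with only a slight lean towards a lower number and no firm direction. The expected step is a 2.0-fold lower number from compound 2 to compound 3 (0.29 log units; within the scatter), which remains an estimate. Compound 3 is estimated at 2500 nM, and is expected to fall between 300 nM and 15000 nM on this read-out.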

Compound 3, half-maximal inhibitory concentration: 2210 nM
The estimate for compound 3 lay 1.1-fold (0.05 log units) above the measured number, and the stated range covers the measured number.
By their numbers in this assay, from the lowest: compound 3; then compound 2; then compound 1.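

Among these compounds, until now, the only measured change at this position, the aromatic carbon ortho to a methoxy group, was the removal of fluoro, which left open whether any group there could beat plain hydrogen. In this assay, amino does so, with a 2.2-fold lower number from compound 2 to compound 3 (0.34 log units; beyond the scatter) as a modest step that lies beyond the usual scatter. Fluoro and amino therefore push the number in opposite directions from the hydrogen of compound 2, and exchanging one for the other gives a 21-fold lower number from compound 1 to compound 3 (1.32 log units; beyond the scatter) as a large step, so the identity of the group at this one place matters far more than the simple fact that hydrogen has been replaced. No supporting measurement is available to explain why these groups differ.

Going by these compounds, three groups at one position give a direction but not a trend, so it remains open whether a hydroxyl, a methylamino or a dimethylamino group would lower the number further or raise it again. An acetamide at the same carbon would show whether the amino result survives when that nitrogen carries a larger group.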